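Tolerability of the fused-core series on HeLa cells

The source may report more compounds than this note shows. Statements on the series, on what has been measured and on what is new or still open speak of the compounds shown alone.

In an ADME assay on HeLa cells (Homo sapiens) for cytotoxicity, read by ATP content, with a stated time of 3 days (a higher number here means that more compound is tolerated, a lower number that less compound is tolerated), all three measured members of this series stop at the assay limit rather than at a number. Compound 1 `O=c1n(Cc2cc3cnccc3n2CCCCO)c2cnccc2n1C1CC1` gives only a limit, > 100000 nM. Compound 2 `Cn1ccc(-n2c(=O)n(Cc3cc4cc(Cl)ccc4n3CCCC#N)c3cnccc32)n1` likewise gives only a limit, > 50000 nM. Compound 3 `CS(=O)(=O)CCCn1c(Cn2c(=O)n(C3CC3)c3ccncc32)cc2cc(Br)ccc21` again gives only a limit, > 50000 nM. Among the measured compounds shown here, compound 2 therefore stands at the limit of > 50000 nM in this assay, at which 2 of the 3 values shown sit, while the single higher reading is the limit of > 100000 nM in this assay, at which 1 of the 3 values shown sits; none of the three tells where tolerance actually ends.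

Compound 4 `COc1ccc(-n2c(=O)n(Cc3cc4cc(Cl)ccc4n3CCCC#N)c3cnccc32)cc1` is not yet measured in this assay. It differs from compound 2 in one place: 4-methoxyphenyl in place of 1-methyl-1H-pyrazol-3-yl on an aromatic nitrogen. For the measured compounds named here, no measured pair differs in a single place, so there is no measured step to read the change against.

Given that every measured member sits at a limit, the step from compound 2 to compound 4 is expected to be none beyond the scatter, as a number no higher from compound 2 to compound 4 (the limit leaves the size open). Compound 4 is therefore expected to remain well tolerated, with an estimated reading of 50000 nM, between 20000 nM and 100000 nM, and most likely to be reported again as a limit rather than as a number.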

Compound 4, half-maximal cytotoxic concentration: > 50000 nM
Compound 4 ended at the assay's limit; the forecaster's own chance of this, stated with the estimate: 80%; the middle value sits exactly at the limit.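

In this assay compound 4 gives > 50000 nM as a limit and not a number. Among the compounds shown here, compound 2 gives > 50000 nM as a limit too, so no step from compound 2 to compound 4 can be read. The compounds shown leave open where tolerance actually ends for any member, and whether 4-methoxyphenyl in place of 1-methyl-1H-pyrazol-3-yl changes it.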